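Cyclopropyl in place of the gem-dimethyl carbon

This account rests on a few compounds, and the source may have more. Where it says the series, first, only, none or still open, it means among the compounds named here.

Compound 1 `CC(C)(C(=O)Nc1ccc(C(=O)Nc2ccc(F)cc2N)cc1)c1ccccc1` belongs to a small set of anilides sharing one core. In an assay on isolated protein for inhibition of histone deacetylase 8 (Homo sapiens), read by fluorescence, tested at 1 uM (on this read-out lower numbers stand for less inhibition and higher numbers for more inhibition at the one concentration tested (going by the name of the read-out)), compound 1 gives 0%. Its nearest neighbour, compound 2 `CC(C)(C(=O)Nc1ccc(C(=O)Nc2ccccc2N)cc1)c1ccccc1`, gives 0% in this assay, and the step of no change at the digits printed from compound 1 to compound 2 (within the scatter) shows hydrogen in place of fluoro on an aromatic carbon. Compound 3 `CC(C)[C@H](C(=O)Nc1ccc(C(=O)Nc2ccccc2N)cc1)c1ccccc1`, which carries a different group on the carbonyl carbon, gives 7% in this assay; its value and that of compound 1 lie within the scatter of each other, so the three numbers stand together at the bottom of the read-out.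

Compound 4 `Nc1cc(F)ccc1NC(=O)c1ccc(NC(=O)C2CC2c2ccccc2)cc1` has not yet been measured. Relative to compound 1 the change is 2-phenylcyclopropyl in place of 1-methyl-1-phenylethyl on a carbonyl carbon. Among the measured compounds shown here, no measured step concerns this part of the molecule: the only step on record, from compound 1 to compound 2, concerns the aromatic fluoro and stayed within the scatter, and the pair compound 2 and compound 3 differs elsewhere without showing a step beyond the scatter. For the measured compounds named here, with every measured value near zero and no precedent for the new group, the expected step of a number 3 percentage points higher from compound 1 to compound 4 (within the scatter) is none beyond the scatter. Compound 4 is therefore estimated at 3% in this assay, within -5% to 15%.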

Compound 4, a percentage reported as inhibition, at one concentration (the size of the read-out at that concentration, not a potency): 14%
Compound 4: middle estimate off by 11 percentage points, on the low side, within the range that was stated.
By their numbers in this assay, from the lowest: compounds 1, 2, 3 and 4 (each within the scatter of the next, the first and the last beyond it).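

Among the compounds shown here, on the carbonyl carbon, 2-phenylcyclopropyl in place of 1-methyl-1-phenylethyl gives a number 14 percentage points higher from compound 1 to compound 4 (beyond the scatter) in this assay and is the first single change in this set to move the read-out beyond the scatter, which shows that this position is not silent, as the change at the aromatic fluoro was. The two groups match in their counts of heavy atoms, hydrogen-bond donors and acceptors, and each holds one six-membered aromatic ring; what differs is the three-membered ring that enters, so the read-out here responds to a change that leaves those counts untouched. Even so, the step is modest, and compound 4 at 14% remains a reading at one concentration, not a potency, and nothing available bears on why the number moved.

Going by these compounds, it stays open whether the phenyl of 2-phenylcyclopropyl is needed, which a plain cyclopropyl or a longer chain such as phenylethyl on the same carbonyl carbon would test, and whether an amine on that phenyl would take the number further. On these data alone, it also stays open whether hydrogen in place of fluoro on an aromatic carbon would leave the value of compound 4 as unmoved as it left that of compound 1.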